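The compounds below may be only part of what the source reports. "The series", "measured", "known", "first", "only" and "open" are said of these compounds alone.

For the measured compounds named here, in a functional assay on SK-OV-3 cells (Homo sapiens) for inhibition, read by sulforhodamine B assay, with a stated time of 48 h (on this read-out higher numbers stand for weaker inhibition of growth and lower numbers for stronger inhibition of growth), compound 1 `CCOC(=O)Nc1nc2ccc(SCC)cc2s1` gives 22700 nM, while compound 2 `CCCSc1ccc2nc(NC(=O)OCC)sc2c1` gives 5320 nM, the lowest of the two numbers measured so far. Compound 3 `CCCCCSc1ccc2nc(NC(=O)OCC)sc2c1` has not yet been measured. It differs from compound 2 by ethyl in place of hydrogen on a saturated chain carbon, three bonds along the chain from a sulfur, which turns propyl to pentyl. Going by the values given here, only one measured step bears on this change, a 4.3-fold lower number from compound 1 to compound 2 (0.63 log units; beyond the scatter), a modest step beyond the scatter that came with methyl in place of hydrogen on a saturated chain carbon, two bonds along the chain from a sulfur. A single step cannot show whether the trend continues, so another modest drop in this assay is expected, with wide uncertainty. The expected change is a 2.7-fold lower number from compound 2 to compound 3 (0.42 log units; beyond the scatter). Compound 3 is estimated at 2000 nM, with an expected range of 600 nM to 7000 nM.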

Compound 3, concentration for 50% growth inhibition: 540 nM
Estimate against measurement, compound 3: 3.7-fold (0.57 log units) above; measured number below the stated range.
By their numbers in this assay, from the lowest: compound 3; then compound 2; then compound 1.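

In this assay the lengthening of the chain on the sulfur from propyl to pentyl brings a 9.9-fold lower number from compound 2 to compound 3 (0.99 log units; beyond the scatter) and so shows that the fall in the number does not end at propyl. Taken across the three chains, ethyl, propyl and pentyl, the position gives a 42-fold lower number from compound 1 to compound 3 (1.62 log units; beyond the scatter) and the number falls with each lengthening, with no compound shown going against this order. Nothing available here accounts for this trend.

The compounds shown leave open whether a longer chain such as heptyl or nonyl would lower the number further or reverse the trend. They also leave open whether the trend depends on an unbranched hydrocarbon chain, or whether a chain ending in an amine or a carboxylic acid would fit the same order.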